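A few compounds are considered here, and "the series" means these few. Any claim that something is new, unique, unknown or untested is made for them only; others in the source may bear on it.

In a functional assay for agonist activity at G protein-coupled receptor 88 (Homo sapiens), read by HTRF and cAMP accumulation (a lower number here means that less compound is needed, a higher number that more compound is needed for the effect), compound 1 (`CC[C@@H](C)[C@H](N)CN(C(=O)[C@@H]1C[C@H]1c1ccccc1)c1ccc(-c2ccccc2)cc1`) gives 1.4 nM. Compound 2 (`CC[C@H](C)[C@H](N)CN(C(=O)[C@@H]1C[C@H]1c1ccccc1Cl)c1ccc(-c2ccccc2)cc1`) reaches only a limit of this assay, > 25000 nM (the limit of > 25000 nM in this assay, at which 1 of the 3 values shown sits). Compound 3 (`CC[C@H](C)[C@H](N)CN(C(=O)[C@@H]1C[C@H]1c1ccccc1F)c1ccc(-c2ccccc2)cc1`) gives 650 nM in this assay; among the two numbers shown it is the higher one, and compound 1 sits well below it. For the measured compounds named here, the one measured step, an at least 38-fold lower number from compound 2 to compound 3 (1.58 log units; beyond the scatter), is the only evidence that bears on changes to this aromatic ring, and it concerns a swap of halogen rather than an added one.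

Compound 4 (`CC[C@H](C)[C@H](N)CN(C(=O)[C@@H]1C[C@H]1c1cc(F)ccc1F)c1ccc(-c2ccccc2)cc1`) differs from compound 3 by fluoro in place of hydrogen on an aromatic carbon. Going by the values given here, no measured step covers an added fluoro at this place, so the expectation rests on the large swing seen between compound 2 and compound 3 only as a sign that this ring is sensitive. Compound 4 is therefore expected to change by a 1.5-fold higher number from compound 3 to compound 4 (0.19 log units; within the scatter), a modest step with wide uncertainty. Compound 4 is estimated at 1000 nM, within a range from 200 nM to 6000 nM.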

Compound 4, half-maximal effective concentration: 770 nM
The estimate for compound 4 lay 1.3-fold (0.11 log units) above the measured number; low and high end bracket the measured number.
By their numbers in this assay, from the lowest: compound 1; then compounds 3 and 4 (each within the scatter of the next). At a limit, above all of these: compound 2.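

In this assay, fluoro on this aromatic carbon, meta to a large group and para to a fluoro group, gives a 1.2-fold higher number from compound 3 to compound 4 (0.07 log units; within the scatter), so the ring accepts this addition with no separation between the two compounds, in contrast to the large step seen for the halogen swap. The 2,5-difluorophenyl group likewise stands well apart from the 2-chlorophenyl group, with an at least 32-fold lower number from compound 2 to compound 4 (1.51 log units; beyond the scatter). That step rests on a limit and not on a number: the limit of > 25000 nM in this assay, at which 1 of the 4 values shown sits.

Compound 1 differs from compound 3 and compound 4 in more than one place, so its gap to them cannot be assigned to any single change. As far as these compounds go, whether this same aromatic carbon would also accept methoxy, trifluoromethyl or an amine remains open.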